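Anilide in place of benzothiazolyl amide: compound 4

The source may hold more compounds than are shown below. What is called first, only, known or untested is meant among the compounds shown, and "the series" means these compounds.

Measured so far:
compound 1 `O=C(CCCCCCNC(=O)C(O)(O)C(F)(F)F)Nc1nc2ccccc2s1` — 2370 nM
compound 2 `COc1ccc2sc(NC(=O)CCCCCCNC(=O)C(O)(O)C(F)(F)F)nc2c1` — 2180 nM
compound 3 `C/C(=N\O)C(=O)NCCCCC(=O)Nc1ccccc1` — limit only

In a functional assay on HCT-116 cells (Homo sapiens) for inhibition, read by colorimetric assay, with a stated time of 3 days (on this read-out lower numbers stand for stronger inhibition and higher numbers for weaker inhibition), compound 1 gives 2370 nM, the highest of the two numbers recorded. Compound 2 sits nearest, and the step of a 1.1-fold lower number from compound 1 to compound 2 (0.04 log units; within the scatter) stays within the scatter, so the two cannot be ranked. Compound 3 returns only a limit, > 100000 nM, marking the edge of what this assay can report (the limit of > 100000 nM in this assay, at which 1 of the 3 values shown sits).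

Compound 4 `COc1ccc(NC(=O)CCCCCCNC(=O)C(O)(O)C(F)(F)F)cc1` differs from compound 1 by 4-methoxyphenyl in place of 1,3-benzothiazol-2-yl on an amide-type nitrogen. Within the data shown here, no measured step covers this change: the single step recorded, from compound 1 to compound 2, touches a methoxy on the aromatic ring and is within the scatter. The only anilide measured, compound 3, carries a different chain and gives a limit, so it offers no number to anchor a comparison.

Compound 4 is therefore expected to give 9000 nM in this assay, with a wide range from 2000 nM to 60000 nM. The step from compound 1 to compound 4 is estimated at a 3.8-fold higher number from compound 1 to compound 4 (0.58 log units; beyond the scatter), a weakening beyond the scatter, with a real chance that only a limit is returned.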

Compound 4, half-maximal inhibitory concentration: 4520 nM
Estimate against measurement, compound 4: 2.0-fold (0.30 log units) above, within the range that was stated.
By their numbers in this assay, from the lowest: compounds 2, 1 and 4 (each within the scatter of the next, the first and the last beyond it). At a limit, above all of these: compound 3.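

In this assay, replacing the whole aromatic group on the amide-type nitrogen leaves the number within the scatter (a 1.9-fold higher number from compound 1 to compound 4 (0.28 log units; within the scatter)), so 4-methoxyphenyl and 1,3-benzothiazol-2-yl cannot be ranked at this position. The earlier step varied only a methoxy on the aromatic ring, whereas this one shows that the five-membered aromatic ring with its two hetero atoms is not needed to keep a number of this order in this pair. No measurement shown gives a cause for this step.

As far as these compounds go, it remains open whether an unsubstituted phenyl or a pyridine on the same nitrogen would hold this level, and whether the methoxy in compound 4 contributes at all. Also open, from the compounds shown here alone, are the effects of a longer chain and of a hydroxamic acid in place of the end group carrying the trifluoromethyl.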